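The compounds below may be only part of what the source reports. "The series", "measured", "known", "first", "only" and "open" are said of these compounds alone.

In a functional assay on HepG2 cells (Homo sapiens) for antiproliferative activity, read by MTT assay, with a stated time of 48 h (a higher number here means a weaker inhibitor, a lower number a stronger inhibitor), compound 1 `Fc1ccc(CSc2nnc(-c3ccc4c(c3)OCCO4)o2)cc1` gives 38000 nM, compound 2 `Brc1ccccc1CSc1nnc(-c2ccc3c(c2)OCCO3)o1` gives 20000 nM and compound 3 `Clc1ccc(CSc2nnc(-c3ccc4c(c3)OCCO4)o2)cc1` gives 28800 nM. Compound 3 therefore stands level with the other two, since every gap among these values lies within the ordinary scatter of repeated measurements. Compound 4 `Clc1ccccc1CSc1nnc(-c2ccc3c(c2)OCCO3)o1` has the same atoms as compound 3, joined differently: 2-chlorophenyl in place of 4-chlorophenyl on a saturated chain carbon bound to a sulfur. In words, this is 2-chlorophenyl in place of 4-chlorophenyl on a saturated chain carbon bound to a sulfur.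

Among the compounds with values here, no measured pair shows this exact change, but three steps bear on it. The step of a 1.4-fold higher number from compound 2 to compound 3 (0.16 log units; within the scatter) exchanges 2-bromophenyl for 4-chlorophenyl, the step of a 1.9-fold lower number from compound 1 to compound 2 (0.28 log units; within the scatter) exchanges 4-fluorophenyl for 2-bromophenyl, and the step of a 1.3-fold lower number from compound 1 to compound 3 (0.12 log units; within the scatter) puts chloro in place of fluoro. All three stay within the scatter, so no step beyond the scatter is expected in this assay, in either direction. The expected step is a 1.1-fold lower number from compound 3 to compound 4 (0.04 log units; within the scatter). For compound 4 the estimated value is 26000 nM, with an expected range from 13000 nM to 50000 nM.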

Compound 4, half-maximal inhibitory concentration: 22600 nM
Compound 4: middle estimate off by 1.2-fold (0.06 log units), on the high side; low and high end bracket the measured number.
By their numbers in this assay, from the lowest: compounds 2, 4, 3 and 1 (each within the scatter of the next).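

In this assay, within the data shown here, the earlier compounds never set the same halogen at two places on the phenyl ring, and this pair does: 2-chlorophenyl in place of 4-chlorophenyl gives a 1.3-fold lower number from compound 3 to compound 4 (0.11 log units; within the scatter) and so shows no readable effect of moving the chlorine between these two places. The step of a 1.1-fold higher number from compound 2 to compound 4 (0.05 log units; within the scatter) for the exchange of one halogen for another and the step of a 1.7-fold lower number from compound 1 to compound 4 (0.23 log units; within the scatter) for 2-chlorophenyl in place of 4-fluorophenyl likewise leave all four compounds level. No available evidence explains this flat result.

Every compound shown carries a single halogen on the phenyl ring. On these data alone, whether a methoxy group, an amine or a carboxylic acid on that ring, or a longer chain at the carbon bound to the sulfur, would shift the number beyond the scatter remains open.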